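Dimethylation of the aminomethyl group in the biphenyl series

The source may report more compounds than this note shows. Statements on the series, on what has been measured and on what is new or still open speak of the compounds shown alone.

For the measured compounds named here, compound 2 `NCc1nnc(-c2ccccc2-c2ccccc2)s1` gives, in a functional assay on the whole organism with Mus musculus as the target (a lower number here means that less compound is needed, a higher number that more compound is needed for the effect), 20 mg/kg; this is the only plain number in the set. Compound 1 `CNCc1nnc(-c2ccccc2)s1` reaches only the limit > 200 mg/kg in this assay, which is not a number. The step to compound 3 `CN(C)Cc1nnc(-c2ccccc2-c2ccccc2)s1` brings (dimethylamino in place of amino on a saturated chain carbon bound to an aromatic carbon). Going by the values given here, no measured pair isolates this single change; compound 1 differs from compound 2 in two places, so its limit of > 200 mg/kg in this assay, at which 1 of the 2 values shown sits, says nothing about dimethylation alone. A step of moderate size toward a higher dose is expected, a 2.5-fold higher number from compound 2 to compound 3 (0.40 log units; beyond the scatter), though it may not exceed the scatter. Compound 3 is estimated at 50 mg/kg, between 15 mg/kg and 200 mg/kg.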

Compound 3, dose for half-maximal effect: 32 mg/kg
Estimate against measurement, compound 3: 1.6-fold (0.19 log units) above; measured number inside the range.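

For the compounds shown here, replacing amino with dimethylamino on a saturated chain carbon bound to an aromatic carbon gives the first readable single-place step: a 1.6-fold higher number from compound 2 to compound 3 (0.20 log units; within the scatter) in this assay. At this position, therefore, the two compounds cannot be told apart in this read-out, although the hydrogen-bond donor of amino is absent from dimethylamino. Nothing available gives a cause for this result.

From the compounds shown here alone, it remains open how diethylamino or a longer chain at this position would read. Also open, going by these compounds, is whether the same step would read alike on the core of compound 1.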